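Ortho Substituent Variation on the Shared Core

The source may report more compounds than this note shows. Statements on the series, on what has been measured and on what is new or still open speak of the compounds shown alone.

Compound 1 `c1ccc(-c2nc3cccnc3o2)cc1` gives 55% in a functional assay on the whole organism for inhibition, with Rattus norvegicus as the target, at a dose of 30 mg/kg; a lower number here means less inhibition, a higher number more inhibition at the dose given (going by the name of the read-out). Compound 2 `Brc1ccccc1-c1nc2cccnc2o1` gives 31%, a step of a number 24 percentage points lower from compound 1 to compound 2 (beyond the scatter). Compound 3 `Nc1ccccc1-c1nc2cccnc2o1` gives 13%, the lowest of the three numbers, with a step of a number 42 percentage points lower from compound 1 to compound 3 (beyond the scatter) and of a number 18 percentage points lower from compound 2 to compound 3 (beyond the scatter). Compound 4 `Cc1ccccc1-c1nc2cccnc2o1` differs from compound 3 as follows: methyl in place of amino on an aromatic carbon. The two steps that bear on it are those ending at compound 3, both downward and beyond the scatter; replacing the amino group is therefore expected to move the number back toward the range spanned by compounds 1 and 2, most likely near compound 2. Compound 4 is estimated at 35% in this assay, within 15% to 55%, an expected step of a number 22 percentage points higher from compound 3 to compound 4 (beyond the scatter).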

Compound 4, a percentage reported as inhibition, in the whole organism at one dose (the size of the read-out at that dose, not a potency): 3%
For compound 4 the middle estimate is 32 percentage points above the measured one; the whole stated range lies above it.
By their numbers in this assay, from the lowest: compounds 4 and 3 (each within the scatter of the next); then compound 2; then compound 1.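

In this assay the change from amino to methyl at this position reads a number 10 percentage points lower from compound 3 to compound 4 (within the scatter), so the loss of the hydrogen-bond donor and acceptor counted for amino brings no separation between the two groups. Methyl also reads a number 28 percentage points lower from compound 2 to compound 4 (beyond the scatter) and a number 52 percentage points lower from compound 1 to compound 4 (beyond the scatter), which extends the set of groups at this place that give a lower number than hydrogen to bromo, amino and methyl. Nothing available explains why methyl stands with amino and not with bromo.

On these data alone, whether a fluoro, hydroxyl or methoxy group at this place would stay closer to hydrogen remains open.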